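This account rests on a few compounds, and the source may have more. Where it says the series, first, only, none or still open, it means among the compounds named here.

Compound 2 `O=C(CBr)c1cc(C(F)(F)F)cc(C(F)(F)F)c1` carries a (bromomethyl)carbonyl on the shared core. In an ADME assay for pharmacokinetics, read by HPLC, in phosphate buffer, with a stated time of 72 h, at pH 7.4, tested at 250 uM (on this read-out lower numbers stand for a shorter-lived compound and higher numbers for a longer-lived compound), compound 2 gives < 0.017 h, which is a limit of the assay rather than a number (the limit of < 0.017 h in this assay, at which 1 of the 2 values shown sits). Compound 1 `C=Cc1cc(C(F)(F)F)cc(C(F)(F)F)c1` differs from it at that aromatic carbon alone. In this assay compound 1 gives > 50 h, likewise a limit (the limit of > 50 h in this assay, at which 1 of the 2 values shown sits). For the measured compounds named here, the only measured step, an at least 2900-fold lower number from compound 1 to compound 2 (3.46 log units; beyond the scatter), is thus bounded by limits at both ends, yet it shows that exchanging the group on that aromatic carbon shifts the half-life very far. Compound 3 `Fc1cc(C(F)(F)F)cc(C(F)(F)F)c1` has not yet been measured; its change from compound 2 is fluoro in place of (bromomethyl)carbonyl on an aromatic carbon. The (bromomethyl)carbonyl that entered in the measured step leaves again here, so compound 3 is expected to sit at the long-lived end of the numbers shown rather than at the short-lived end where compound 2 stands. In this assay the expected step is an at least 7000-fold higher number from compound 2 to compound 3 (3.84 log units; beyond the scatter), a large rise. Compound 3 is expected to give about 120 h, within 30 h to 500 h, most likely reported again only as a limit.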

Compound 3, half-life: 11 h
Compound 3: middle estimate off by 11-fold (1.04 log units), on the high side; measured number outside the range, below it.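

For the compounds shown here, compound 3 gives the first value at this aromatic carbon that is a number rather than a limit, so this assay now has a point inside the span that the two limits marked out. Fluoro in place of (bromomethyl)carbonyl brings an at least 640-fold higher number from compound 2 to compound 3 (2.81 log units; beyond the scatter), but fluoro in place of vinyl still brings an at least 4.5-fold lower number from compound 1 to compound 3 (0.65 log units; beyond the scatter), so the group on this carbon matters even among compounds that lack the (bromomethyl)carbonyl. Each of these steps has one end at a limit of the assay, so each gives only a minimum size and the true gaps may be wider.

The compounds shown leave open where other groups on this same aromatic carbon would fall in this assay, for instance an amine, a carboxylic acid or a longer chain, and whether the half-life follows any single feature of the group there. They also leave open what becomes of compound 2 and compound 3 during the measurement, since the half-lives alone do not tell what forms from them.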